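A Trifluoromethyl Analogue of an Aminothiophene Ketone

The source may hold more compounds than are shown below. What is called first, only, known or untested is meant among the compounds shown, and "the series" means these compounds.

Compound 1 `Nc1sc2cnccc2c1C(=O)c1ccccc1`: 0%
Compound 2 `Nc1sc2cnccc2c1C(=O)c1ccc(Br)cc1`: 0%

In an assay on CHO cells for displacement of a labelled ligand from adenosine receptor A3 (Homo sapiens), tested at 10 uM (a lower number here means less inhibition, a higher number more inhibition at the concentration tested (going by the name of the read-out)), compound 1 gives 0%, and compound 2 gives 0%. Compound 1 therefore stands level with compound 2 at the digits shown, and the step of no change at the digits printed from compound 1 to compound 2 (within the scatter) lies within the scatter. Compound 3 `Nc1sc2cnccc2c1C(=O)c1cccc(C(F)(F)F)c1` differs from compound 1 by trifluoromethyl in place of hydrogen on an aromatic carbon. For the measured compounds named here, the only measured step that bears on this change, the one from compound 1 to compound 2, brought a new group onto the same six-membered aromatic ring of carbon only and moved nothing. The step of no change at the digits printed from compound 1 to compound 3 (within the scatter) is accordingly expected to be none beyond the scatter. Compound 3 is estimated to give 0%, ranging from -10% to 12%.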

Compound 3, a percentage reported as inhibition, at one concentration (the size of the read-out at that concentration, not a potency): 0%
For compound 3 middle estimate and measured number coincide at the digits printed; the measured number falls inside the stated range.
By their numbers in this assay, from the lowest: compounds 1, 2 and 3 (each within the scatter of the next).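

With trifluoromethyl in place of hydrogen on an aromatic carbon, meta to a large group, this assay shows no change at the digits printed from compound 1 to compound 3 (within the scatter). The six-membered aromatic ring of carbon only has thus taken a second kind of substituent, here with 4 heavy atoms, and compound 3 still shows no inhibition at the concentration tested. Nothing available explains this flat result. From the compounds shown here alone, whether an amine, a carboxylic acid or a longer chain at this position would give any inhibition remains open. So does whether any change to the shared core outside this ring would do so.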